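From fluoro to methoxy on the terminal aromatic ring

This account rests on a few compounds, and the source may have more. Where it says the series, first, only, none or still open, it means among the compounds named here.

Compound 1 `CNC(=O)c1cc(Oc2ccc(NC(=O)c3cc(-c4ccccc4)ncn3)cc2)ccn1`: 18200 nM
Compound 2 `CNC(=O)c1cc(Oc2ccc(NC(=O)c3cc(-c4ccc(F)cc4)ncn3)cc2)ccn1`: > 100000 nM (a limit)

In a functional assay on MCF7 cells (Homo sapiens) for cytotoxicity, read by MTT assay, with a stated time of 72 h (a higher number here means a weaker inhibitor, a lower number a stronger inhibitor), compound 2 stands at > 100000 nM, which is a limit of the assay and not a number. Compound 3 `CNC(=O)c1cc(Oc2ccc(NC(=O)c3cc(-c4ccc(OC)cc4)ncn3)cc2)ccn1` carries methoxy in place of fluoro on an aromatic carbon. Within the data shown here, one measured step bears on this change: an at least 5.4-fold higher number from compound 1 to compound 2 (0.73 log units; beyond the scatter). That step put fluoro in place of hydrogen on an aromatic carbon, and this fluoro is the group that now leaves. Among the measured compounds shown here, no measured step involves methoxy, so the size of the change is uncertain. For the measured compounds named here, a modest step towards a lower number is expected in this assay, with compound 1 at 18200 nM as the only measured number to lean on. The expected change is an at least 2.2-fold lower number from compound 2 to compound 3 (0.34 log units; beyond the scatter). For compound 3 the estimated value is 45000 nM, with an expected range from 15000 nM to 100000 nM.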

Compound 3, half-maximal inhibitory concentration: 29200 nM
Compound 3: the middle estimate sits 1.5-fold (0.19 log units) above what was measured; the range from low to high includes it.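

At this carbon, para to a large group, methoxy in place of fluoro brings the reading in this assay back to a measured number, giving an at least 3.4-fold lower number from compound 2 to compound 3 (0.53 log units; beyond the scatter). Set against the unsubstituted phenyl, methoxy in place of hydrogen gives a 1.6-fold higher number from compound 1 to compound 3 (0.21 log units; within the scatter), so methoxy at this position leaves the number within the scatter of the parent, whereas fluoro alone gave an at least 5.4-fold higher number from compound 1 to compound 2 (0.73 log units; beyond the scatter). For compound 2 the reading is a limit of the assay and not a number: the limit of > 100000 nM in this assay, at which 1 of the 3 values shown sits.

As far as these compounds go, whether another group at this carbon, such as an amine or a carboxylic acid, would take the number clearly below that of compound 1 remains open. From the compounds shown here alone, the full size of the step from fluoro to methoxy also stays open, as only its lower bound is known.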